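The compounds below may be only part of what the source reports. "The series", "measured", "known", "first", "only" and "open" are said of these compounds alone.

Measured compounds:
- compound 1, `Cc1cccc(C(=O)n2c(-c3cn(-c4ccccc4)nc3-c3ccc(C(F)(F)F)cc3)nc3ccccc32)c1`: 154000 nM
- compound 2, `O=C(c1ccccc1)n1c(-c2cn(-c3ccccc3)nc2-c2ccc(F)cc2)nc2ccccc21`: 180000 nM

Of the compounds shown here, two have been tested in an ADME assay on HEK-293T cells (Homo sapiens) for cytotoxicity, read by MTT assay, with a stated time of 24 h; on this read-out higher numbers stand for lower toxicity in this test and lower numbers for higher toxicity in this test. Compound 2 gives 180000 nM in this assay, and compound 1 gives 154000 nM; the gap between these two numbers is within the scatter, so neither can be set above the other. Among the compounds with values here, compound 2 therefore stands level with the only other measured compound.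

The step to compound 3, `O=C(c1ccccc1)n1c(-c2cn(-c3ccccc3)nc2-c2ccc(C(F)(F)F)cc2)nc2ccccc21`, changes a single group: trifluoromethyl in place of fluoro on an aromatic carbon. The same difference, read one bond further out, is 4-fluorophenyl to 4-(trifluoromethyl)phenyl. Within the data shown here, no measured pair shows this exact change on its own. Compound 1 also carries a 4-(trifluoromethyl)phenyl and gives 154000 nM, a number within the scatter of that of compound 2, so the trifluoromethyl-bearing compound already seen does not stand apart from the fluoro-bearing one.

On that basis the step is expected to be small, a 1.1-fold lower number from compound 2 to compound 3 (0.04 log units; within the scatter), with no direction beyond the scatter. Compound 3 is estimated to give 165000 nM in this assay, with a range from 90000 nM to 300000 nM.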

Compound 3, half-maximal cytotoxic concentration: 168000 nM
Estimate against measurement, compound 3: 1.0-fold (0.01 log units) below; the measured number falls inside the stated range.
By their numbers in this assay, from the lowest: compounds 1, 3 and 2 (each within the scatter of the next).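

Read as a direct pair, trifluoromethyl in place of fluoro on this aromatic carbon, para to a large group, gives a 1.1-fold lower number from compound 2 to compound 3 (0.03 log units; within the scatter) in this assay, so the two groups cannot be told apart at this position, something the earlier compounds could not show because they differed in more than one place. Compound 3 also links compound 1 to the series through a second single change, hydrogen in place of methyl on an aromatic carbon, which gives a 1.1-fold higher number from compound 1 to compound 3 (0.04 log units; within the scatter), so this change likewise leaves the number within the scatter in this assay. Nothing available here bears on why these changes leave the read-out level.

The compounds shown leave open whether any other group on the trifluoromethyl-bearing aromatic carbon, such as an amine or a carboxylic acid, would give a number beyond the scatter of these three. They also leave open whether the level numbers would hold with a longer chain in place of the methyl of compound 1, since only hydrogen and methyl are compared at that place.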